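Removing a methyl from compound 2: clearance in mice

A few compounds are considered here, and "the series" means these few. Any claim that something is new, unique, unknown or untested is made for them only; others in the source may bear on it.

Measured compounds:
compound 1 `CC(C(=O)O)c1nn(Cc2cn3cc(OCC4CC4)c(C(F)(F)F)cc3n2)c2ccccc2c1=O`: 4.17 mL/min/kg
compound 2 `C[C@H](C(=O)O)n1nc(Cn2cc3cc(OCC4CC4)c(Cl)cc3n2)c2ccccc2c1=O`: 9 mL/min/kg

In an ADME assay on the whole organism (Mus musculus, strain CD1) for pharmacokinetics, read by LC-MS, with a stated time of 24 h, at a dose of 1 mg/kg by the intravenous route (on this read-out lower numbers stand for slow clearance and higher numbers for fast clearance), compound 2 gives 9 mL/min/kg, the higher of the two numbers recorded. Its nearest neighbour on this read-out is compound 1, which in this assay gives 4.17 mL/min/kg, a gap that lies beyond the scatter of repeated measurements. Within the data shown here, no single-point step between the two measured compounds exists, so only these two values can be compared.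

Compound 3 `O=C(O)Cn1nc(Cn2cc3cc(OCC4CC4)c(Cl)cc3n2)c2ccccc2c1=O` differs from compound 2 by one change: hydrogen in place of methyl on a saturated chain carbon bound to an aromatic nitrogen and a carbonyl carbon, that is, 1-carboxyethyl becomes carboxymethyl. Nothing measured speaks directly to this change, so a step of small size is expected, a 1.1-fold higher number from compound 2 to compound 3 (0.05 log units; within the scatter), with no direction secured beyond the scatter. Compound 3 is therefore estimated to give 10 mL/min/kg in this assay, in a range from 5 mL/min/kg to 20 mL/min/kg.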

Compound 3, clearance in the Mus musculus assay: 5.67 mL/min/kg
Estimate against measurement, compound 3: 1.8-fold (0.25 log units) above; measured number inside the range.
By their numbers in the Mus musculus assay, from the lowest: compounds 1, 3 and 2 (each within the scatter of the next, the first and the last beyond it).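

In the Mus musculus assay the change from 1-carboxyethyl to carboxymethyl gives a 1.6-fold lower number from compound 2 to compound 3 (0.20 log units; within the scatter) and so provides the first matched pair, showing that this saturated chain carbon can lose its methyl without a difference in clearance that stands clear of repeat measurements. In a physicochemical assay for lipophilicity, at pH 7.4 (a higher number here means a more lipophilic compound, a lower number a more polar compound), compound 2 gives 2.99 and compound 3 gives 2.79 in a distribution coefficient comparison that reads a number 0.20 log units lower from compound 2 to compound 3 (within the scatter) and so leaves this change inside the scatter on both read-outs. No measured finding on hand accounts for either result.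

The compounds shown leave open how clearance would respond to a longer chain, such as 1-carboxypropyl, or to an amine on this carbon. They also leave open what an amide in place of the carboxylic acid would do on either read-out.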